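The source may hold more compounds than are shown below. What is called first, only, known or untested is meant among the compounds shown, and "the series" means these compounds.

Measured compounds:
Compound 1, `Cc1ccc(F)cc1NC(=O)CN1CCN(c2nnc(Cc3ccccc3)c3ccccc23)CC1` — 19200 nM
Compound 2, `Cc1ccc(F)cc1NC(=O)CN1CCN(c2nnc(Cc3ccncc3)c3ccccc23)CC1` — 6.4 nM
Compound 3, `O=C(CN1CCN(c2nnc(Cc3ccncc3)c3ccccc23)CC1)Nc1cc(C(F)(F)F)ccc1Cl` — 3.7 nM

In a functional assay on MDA-MB-231 cells (Homo sapiens) for cytotoxicity, read by MTT assay, with a stated time of 72 h (a higher number here means a weaker inhibitor, a lower number a stronger inhibitor), compound 1 gives 19200 nM, the highest of the three numbers; its nearest neighbour is compound 2 with 6.4 nM, and the furthest is compound 3 with 3.7 nM. The step of a 3000-fold lower number from compound 1 to compound 2 (3.48 log units; beyond the scatter) shows how strongly the pyridin-4-yl group moves this series, while the step of a 1.7-fold lower number from compound 2 to compound 3 (0.24 log units; within the scatter) shows that a change on the amide-type nitrogen, at least in the pyridin-4-yl series, leaves the number within the scatter.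

Compound 4, `O=C(CN1CCN(c2nnc(Cc3ccccc3)c3ccccc23)CC1)Nc1ccc(F)c(Cl)c1`, has not yet been measured. It keeps the phenyl group of compound 1 and differs from compound 1 only at the amide-type nitrogen: 3-chloro-4-fluorophenyl in place of 5-fluoro-2-methylphenyl on an amide-type nitrogen. For the measured compounds named here, the one measured step that bears on such a change is a 1.7-fold lower number from compound 2 to compound 3 (0.24 log units; within the scatter), which lay within the scatter; no measured step tests this change with the phenyl group in place. Compound 4 is therefore expected to stay close to compound 1 in this assay, with a step of about a 1.1-fold lower number from compound 1 to compound 4 (0.05 log units; within the scatter), which is no step beyond the scatter. The estimate for compound 4 is 17000 nM, with a range from 5000 nM to 60000 nM.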

Compound 4, half-maximal inhibitory concentration: 7360 nM
The estimate for compound 4 lay 2.3-fold (0.36 log units) above the measured number, and the stated range covers the measured number.
By their numbers in this assay, from the lowest: compounds 3 and 2 (each within the scatter of the next); then compound 4; then compound 1.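

In this assay, for the compounds shown here, the swap to 3-chloro-4-fluorophenyl on the amide-type nitrogen gives a 2.6-fold lower number from compound 1 to compound 4 (0.42 log units; beyond the scatter) as a modest step, the first step at this nitrogen that lies beyond the scatter, and it is read with the phenyl group in place. Going by these compounds alone, the only earlier step at this nitrogen was a 1.7-fold lower number from compound 2 to compound 3 (0.24 log units; within the scatter) with a different pair of aryl groups and with pyridin-4-yl in place, so the two do not test the same change, and the new step remains small beside a 3000-fold lower number from compound 1 to compound 2 (3.48 log units; beyond the scatter) as the measure of what the pyridin-4-yl swap does. Nothing available here accounts for the new step.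

The compounds shown leave open whether 3-chloro-4-fluorophenyl on this nitrogen would give a similar step with pyridin-4-yl in place of phenyl. They also leave open how an aliphatic amine or a longer chain in place of the aryl group on the amide-type nitrogen would read in this assay for either series.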